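The compounds below may be only part of what the source reports. "The series", "measured", "known", "first", "only" and "open" are said of these compounds alone.

Three compounds have been measured in an ADME assay on MDCKII-LE cells (Canis lupus familiaris) for permeability; on this read-out lower numbers stand for lower permeability and higher numbers for higher permeability:

- compound 1 `Cc1cnc(NC(=O)c2cc(Oc3cnc(C(=O)N4CCC4)cn3)c3cc(C)oc3c2)cn1`: 17.4 10^-6 cm/s
- compound 2 `Cc1cnc(NC(=O)c2cc(Oc3cnc(C(=O)N4CCCC4)cn3)c3cc(C)oc3c2)cn1`: 15.8 10^-6 cm/s
- compound 3 `COC1CN(C(=O)c2cnc(Oc3cc(C(=O)Nc4cnccn4)cc4oc(C)cc34)cn2)C1`: 21.8 10^-6 cm/s

The value of compound 3 lies within the scatter of the values of both compound 1 and compound 2, so the three cannot be told apart in this assay. The next compound to be measured is compound 4 `Cc1cc2c(Oc3cnc(C(=O)N(C)C)cn3)cc(C(=O)Nc3cnccn3)cc2o1`, which differs from compound 3 by one change: dimethylamino in place of 3-methoxyazetidin-1-yl on a carbonyl carbon. In words, dimethylamino stands in place of 3-methoxyazetidin-1-yl on a carbonyl carbon.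

Among the measured compounds shown here, only one measured step bears on this change. It also exchanges the group on a carbonyl carbon, with pyrrolidin-1-yl in place of azetidin-1-yl, and it is a 1.1-fold lower number from compound 1 to compound 2 (0.04 log units; within the scatter). That step stays within the scatter, but it is a single step and involves a different pair of groups, so it gives only modest support. No step beyond the scatter is therefore expected in this assay. The estimated step is a 1.1-fold lower number from compound 3 to compound 4 (0.04 log units; within the scatter). For compound 4 the expected value is 20 10^-6 cm/s, with an estimated range from 12 10^-6 cm/s to 32 10^-6 cm/s.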

Compound 4, apparent permeability: 30 10^-6 cm/s
The estimate for compound 4 lay 1.5-fold (0.18 log units) below the measured number; low and high end bracket the measured number.
By their numbers in this assay, from the lowest: compounds 2, 1, 3 and 4 (each within the scatter of the next).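

In this assay, the exchange of 3-methoxyazetidin-1-yl for dimethylamino on a carbonyl carbon gives a 1.4-fold higher number from compound 3 to compound 4 (0.14 log units; within the scatter). Until this step, every compound carried a ring amine at this place, whereas compound 4 shows that an open group with no ring, fewer heavy atoms and no hydrogen-bond acceptor still leaves the read-out within the scatter. Nothing available here offers an explanation for this step.

On these data alone, since this single step removes the ring and the methoxy group together, the contribution of each remains open. As far as these compounds go, it also remains open whether a longer chain such as diethylamino, or a group carrying a basic amine or a carboxylic acid at this place, would stay within the scatter in this assay.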